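The source may report more compounds than this note shows. Statements on the series, on what has been measured and on what is new or still open speak of the compounds shown alone.

Compound 1 `O=c1cc(N2CCNCC2)oc2ccccc12` gives 56000 nM
Compound 2 `CCCCOc1ccc2c(N3CCNCC3)cc(=O)oc2c1C` gives 2790 nM
Compound 3 `O=c1cc(N2CCNCC2)c2ccc(OCc3cccnc3)cc2o1` gives 21300 nM

All three values come from a functional assay on a cell-free system (plasma, Homo sapiens) for inhibition, with Plasma (Rattus norvegicus) as the target (a lower number here means a stronger inhibitor, a higher number a weaker inhibitor), and were read as half-maximal inhibitory concentrations. Compound 2 has the lowest number of the three, which makes it the strongest inhibitor so far. Compound 3 and compound 1 both sit above it by more than the scatter.

The next compound is compound 4 `CCOCOc1ccc2c(N3CCNCC3)cc(=O)oc2c1C`, which differs from compound 2 in a single place. The change is ethoxy in place of propyl on a saturated chain carbon bound to an oxygen on an aromatic ring and it puts ethoxy in place of propyl on a saturated chain carbon bound to an oxygen on an aromatic ring. Read one bond further out, butoxy becomes ethoxymethoxy.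

Within the data shown here, no two measured compounds differ in only one place, so the data give no direct size for such a swap. In this assay only a small move toward a higher number is expected, probably within the scatter. The estimated step is a 1.4-fold higher number from compound 2 to compound 4 (0.16 log units; within the scatter) and remains an expectation until tested. For compound 4 the expected value is 4000 nM within an estimated range from 1500 nM to 12000 nM until a measurement exists.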

Compound 4, half-maximal inhibitory concentration: 1800 nM
Compound 4: middle estimate off by 2.2-fold (0.35 log units), on the high side; the range from low to high includes it.
By their numbers in this assay, from the lowest: compounds 4 and 2 (each within the scatter of the next); then compound 3; then compound 1.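

In this assay the swap gives a 1.6-fold lower number from compound 2 to compound 4 (0.19 log units; within the scatter) and so leaves compound 2 and compound 4 indistinguishable. Among these compounds, this is the first comparison between two compounds that differ in only one place. It shows that on a saturated chain carbon bound to an oxygen on an aromatic ring, ethoxy can stand in place of propyl, adding a hydrogen-bond acceptor to the chain without a step beyond the scatter, though no measurement here accounts for this result.

As far as these compounds go, whether the same position also accepts a longer chain, an amine or a carboxylic acid remains open. So does whether ethoxy in place of propyl would give a similar step on the core of compound 3, which carries a different side chain.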